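The source may report more compounds than this note shows. Statements on the series, on what has been measured and on what is new or still open speak of the compounds shown alone.

Measured in a functional assay on BGC-823 cells (Homo sapiens) for antiproliferative activity, with a stated time of 48 h; on this read-out lower numbers stand for stronger inhibition and higher numbers for weaker inhibition:
- compound 1 `C=CCN1c2c(N)nc(N)nc2CCC1CN(C)c1ccc(C(=O)N[C@@H](CCC(=O)O)C(=O)O)cc1`: 2090 nM
- compound 2 `Cc1ccc(S(=O)(=O)N2c3c(N)nc(N)nc3CCC2CN(C)c2ccc(C(=O)N[C@@H](CCC(=O)O)C(=O)O)cc2)cc1`: 289 nM

Of these two, compound 2 stands lowest at 289 nM, so it is the stronger inhibitor in this assay. For the measured compounds named here, the only measured step is a 7.2-fold lower number from compound 1 to compound 2 (0.86 log units; beyond the scatter), a modest one, with (4-methylphenyl)sulfonyl in place of allyl on a nitrogen on an aromatic ring in a ring.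

Compound 3 `CN(CC1CCc2nc(N)nc(N)c2N1C=O)c1ccc(C(=O)N[C@@H](CCC(=O)O)C(=O)O)cc1` changes the same nitrogen, with formyl in place of (4-methylphenyl)sulfonyl on a nitrogen on an aromatic ring in a ring. Going by the values given here, no measured compound carries formyl, so the data cannot place this group directly. Among the compounds with values here, the one guide is a 7.2-fold lower number from compound 1 to compound 2 (0.86 log units; beyond the scatter), the only measured exchange at this nitrogen. It shows that the number can move clearly when the group there changes, and that compound 2 holds the lower end so far. A move to a higher number is therefore expected, probably of somewhat smaller size than that step, though the uncertainty is wide. The expected change is a 2.9-fold higher number from compound 2 to compound 3 (0.47 log units; beyond the scatter). For compound 3 the estimate is 850 nM, with an expected range of 200 nM to 3500 nM.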

Compound 3, half-maximal inhibitory concentration: 6900 nM
Compound 3: the middle estimate sits 8.1-fold (0.91 log units) below what was measured, and the stated range ends below it.
By their numbers in this assay, from the lowest: compound 2; then compound 1; then compound 3.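

For the compounds shown here, the third group shows that this nitrogen can push the number in both directions, which the single earlier exchange could not show. In this assay the exchange of (4-methylphenyl)sulfonyl for formyl on a nitrogen on an aromatic ring in a ring gives a 24-fold higher number from compound 2 to compound 3 (1.38 log units; beyond the scatter), a larger move than a 7.2-fold lower number from compound 1 to compound 2 (0.86 log units; beyond the scatter), and formyl also falls short of allyl, with a 3.3-fold higher number from compound 1 to compound 3 (0.52 log units; beyond the scatter), so compound 1 now sits between the other two, with allyl raising or lowering the number depending on the group it gives way to. Nothing available here accounts for this order of the three groups.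

The compounds shown leave open whether the lower number of compound 2 goes with the sulfonyl or with the six-membered aromatic ring of carbon only, since (4-methylphenyl)sulfonyl brings both and formyl brings neither. A methylsulfonyl group or a benzoyl group on this nitrogen would separate the two, and a plain hydrogen there would show where the shared core stands without any of these groups.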